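Hydroxyphenyl position in the series: compound 1 to compound 4

This account rests on a few compounds, and the source may have more. Where it says the series, first, only, none or still open, it means among the compounds named here.

Values so far in a functional assay on DU-145 cells (Homo sapiens) for cytotoxicity, read by ELISA, with a stated time of 2 days; a higher number here means a weaker inhibitor, a lower number a stronger inhibitor
- compound 1 `Oc1cccc(-c2cc(-c3ccccc3)cc(-c3ccccc3)n2)c1` gives 18000 nM
- compound 2 `Oc1cccc(-c2cc(-c3ccccc3)cc(-c3ccsc3)n2)c1` gives 11700 nM
- compound 3 `Oc1cccc(-c2cc(-c3ccccc3)cc(-c3ccncc3)n2)c1` gives 19200 nM
- compound 4 `Oc1ccc(-c2cc(-c3ccccc3)cc(-c3ccccc3)n2)cc1` is not yet measured

Compound 1 stands within the scatter of both other measured compounds, so the three cannot be ordered. The change to compound 4 is 4-hydroxyphenyl in place of 3-hydroxyphenyl on an aromatic carbon on an aromatic carbon next to the ring nitrogen. Among the compounds with values here, no measured step touches the hydroxyphenyl group. The steps available exchange phenyl for other groups, namely a 1.5-fold lower number from compound 1 to compound 2 (0.19 log units; within the scatter) and a 1.1-fold higher number from compound 1 to compound 3 (0.03 log units; within the scatter) as well as a 1.6-fold higher number from compound 2 to compound 3 (0.22 log units; within the scatter) in the same series. They bear on the change only indirectly, so no step beyond the scatter is expected in this assay in either direction. The expected change is a 1.1-fold lower number from compound 1 to compound 4 (0.05 log units; within the scatter) as a working estimate. For compound 4 the estimated value is 16000 nM with an expected range from 6000 nM to 40000 nM for now.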

Compound 4, half-maximal inhibitory concentration: 3000 nM
Compound 4: the middle estimate sits 5.3-fold (0.73 log units) above what was measured; measured number outside the range, below it.
By their numbers in this assay, from the lowest: compound 4; then compounds 2, 1 and 3 (each within the scatter of the next).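

4-hydroxyphenyl in place of 3-hydroxyphenyl, next to the ring nitrogen, brings a 6.0-fold lower number from compound 1 to compound 4 (0.78 log units; beyond the scatter) in this assay and is the only step in the series beyond the scatter. The leaving and entering groups have the same atoms, so the step reflects the placement of the hydroxyl alone, while the phenyl exchanges in compound 2 and compound 3 stayed within the scatter. No measurement at hand explains the step.

Open, from the compounds shown here alone, is whether 4-hydroxyphenyl needs its hydroxyl, which 4-methoxyphenyl or 4-aminophenyl would test. Also open, going by these compounds, is whether thiophen-3-yl or pyridin-4-yl behave alike alongside 4-hydroxyphenyl.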